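Working notes on compound 1 and its bromophenyl analogue

The source may report more compounds than this note shows. Statements on the series, on what has been measured and on what is new or still open speak of the compounds shown alone.

The series shares a lactam-bearing core with an amide linker; compound 1 `O=C(COc1ccc(C(=O)/C=C/c2ccc(Cl)cc2Cl)cc1)N[C@H]1CCOC1=O` carries an ether-linked chalcone arm ending in a 2,4-dichlorophenyl group. Going by the values given here, in a functional assay on DU-145 cells (Homo sapiens) for antiproliferative activity, read by MTT assay, with a stated time of 72 h (on this read-out lower numbers stand for stronger inhibition and higher numbers for weaker inhibition), compound 1 gives 8610 nM, the only numerical value in the set. Compound 2 `O=C(CNc1ccccc1F)N[C@H]1CCOC1=O` returns only an assay limit, > 64000 nM. Compound 3 `O=C(CNc1cccc(Cl)c1)N[C@H]1CCOC1=O` likewise returns only an assay limit, > 64000 nM. Among the compounds with values here, compound 1 therefore stands alone as the one measured number, with two of the three values sitting at the limit (the limit of > 64000 nM in this assay, at which 2 of the 3 values shown sit), so no measured step is available to size any change.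

Compound 4 `O=C(COc1ccc(C(=O)/C=C/c2cccc(Br)c2)cc1)N[C@H]1CCOC1=O` differs from compound 1 by 3-bromophenyl in place of 2,4-dichlorophenyl on a double-bonded chain carbon bound to a double-bonded chain carbon. Within the data shown here, no measured pair in this set tests a change of that kind, so the expectation rests on compound 1 alone. The step from compound 1 to compound 4 is expected to be small, within or just beyond the usual scatter, with no strong lean in either direction, as a 1.2-fold higher number from compound 1 to compound 4 (0.06 log units; within the scatter). Compound 4 is accordingly estimated at 10000 nM, with a plausible range from 3000 nM to 32000 nM.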

Compound 4, half-maximal inhibitory concentration: 9800 nM
Beside the measured number, compound 4's estimate is 1.0-fold (0.01 log units) above it; measured number inside the range.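

In this assay the series now has its first measured step, a 1.1-fold higher number from compound 1 to compound 4 (0.06 log units; within the scatter), so 3-bromophenyl and 2,4-dichlorophenyl on a double-bonded chain carbon bound to a double-bonded chain carbon cannot be told apart on this read-out. Going by these compounds alone, at this position, then, replacing the two chlorine atoms of compound 1 with the single bromine atom of compound 4, at a different place on the ring, leaves the result within the scatter, although this holds for this one pair only and sets no trend for halogenated phenyl groups in general. Nothing measured here gives a cause for the step or shows what each group contributes to the result.

As far as these compounds go, two halogenated phenyl groups do not show whether this position would respond to an unsubstituted phenyl, a pyridine ring, a carboxylic acid or a basic amine such as a dimethylaminomethyl group on the phenyl ring, so how much the read-out can vary here remains open. Any steps that would link compound 2 or compound 3 to the other compounds cannot be read: the limit of > 64000 nM in this assay, at which 2 of the 4 values shown sit.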